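Bromo-to-hydrogen swap on the coumarin azide series

The compounds below may be only part of what the source reports. "The series", "measured", "known", "first", "only" and "open" are said of these compounds alone.

Compound 1 `NCCC(=O)N1Cc2ccccc2-c2nnn(-c3cc4cc(Br)ccc4oc3=O)c2-c2ccccc21` and compound 3 `NCCC(=O)N1Cc2ccccc2-c2nnn(-c3cc4ccccc4oc3=O)c2-c2ccccc21` share a large core and differ at one point; compound 2 `[N-]=[N+]=Nc1cc2cc(Br)ccc2oc1=O` is a small fragment, and compound 4 `[N-]=[N+]=Nc1cc2ccccc2oc1=O` is its unmeasured counterpart. In a functional assay on MCF7 cells (Homo sapiens) for cytotoxicity, read by MTT assay, with a stated time of 24 h (on this read-out lower numbers stand for stronger inhibition and higher numbers for weaker inhibition), compound 1 gives 10700 nM, compound 3 gives 12700 nM and compound 2 gives 23700 nM. The number for compound 2 stands higher than that of compound 1 and beyond the scatter, while the pair compound 2 and compound 3 lies within the scatter. The difference between the cores of compound 2 and compound 1 is not broken down here.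

Among the compounds with values here, the one measured instance of the change is hydrogen in place of bromo on an aromatic carbon, which gave a 1.2-fold higher number from compound 1 to compound 3 (0.07 log units; within the scatter). The same change, at the same place, is made from compound 2 to compound 4: hydrogen in place of bromo on an aromatic carbon.

The expected step in this assay is a 1.1-fold higher number from compound 2 to compound 4 (0.06 log units; within the scatter). Within the data shown here, this rests on the single measured step of a 1.2-fold higher number from compound 1 to compound 3 (0.07 log units; within the scatter), which lies within the scatter, so nothing larger is expected here. Among the measured compounds shown here, with only one precedent, the range is kept wide. For compound 4 the number in this assay is estimated at 27000 nM. The estimate for compound 4 runs from 12000 nM to 60000 nM.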

Compound 4, half-maximal inhibitory concentration: 26700 nM
For compound 4 the middle estimate is 1.0-fold (0.00 log units) above the measured one; the range from low to high includes it.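

In this assay, within the data shown here, putting hydrogen in place of bromo on the small azide core gives a 1.1-fold higher number from compound 2 to compound 4 (0.05 log units; within the scatter), so this swap again produces no step that can be told apart from repeat measurements. Set beside the step on the larger core, the result carries over in the sense that both cores show the same near-silent outcome: the same change on two cores in this assay, a 1.2-fold higher number (0.07 log units; within the scatter) from compound 1 to compound 3 and a 1.1-fold higher number (0.05 log units; within the scatter) from compound 2 to compound 4, 1.1-fold (0.02 log units) apart, within the scatter of two such steps

This agreement rests on just two pairs, both within the scatter, so it supports only the statement that the swap changes little on these two cores in this one assay; it does not show that a step of real size would transfer from one core to the other, and it gives no reason for the lack of effect.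

The compounds shown leave open whether a different group on that aromatic carbon, such as chloro, methoxy or a carboxylic acid, would move the number beyond the scatter on either core. Among these compounds, they also leave open whether the swap stays as silent on a core carrying a longer amine chain than the one in compound 1 and compound 3.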